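The source may hold more compounds than are shown below. What is called first, only, known or untested is meant among the compounds shown, and "the series" means these compounds.

Working notes on the series. Compound 1 `Nc1nc(NCc2cnccn2)nc2sc(-c3ccco3)nc12` carries the pyrazin-2-ylmethyl arm on the shared core; in a functional assay on CHO cells for agonist activity at adenosine receptor A2b (Homo sapiens), read by scintillation counting and cAMP accumulation, with a stated time of 150 min, in the presence of a further agent that is not named here (a higher number here means a weaker inhibitor, a lower number a stronger inhibitor), compound 1 gives 13.2 nM. Compound 2 `COc1ccccc1CNc1nc(N)c2nc(-c3ccc(C)o3)sc2n1` differs from compound 1 in more than one place, and in this assay compound 2 gives 389 nM, a higher number than compound 1 by a margin beyond the scatter; compound 1 therefore holds the lowest number of the two measured. Among the compounds with values here, no pair of measured compounds differs in a single place, so no single-point step is known yet. Compound 3 `Nc1nc(NCc2ccccn2)nc2sc(-c3ccco3)nc12` is the next point to be measured: pyridin-2-yl in place of pyrazin-2-yl on a saturated chain carbon bound to a nitrogen on an aromatic ring. The saturated chain carbon bound to a nitrogen on an aromatic ring and the six-membered aromatic ring are kept. Within the data shown here, with no measured step of this kind to lean on, the expected step of a 1.1-fold higher number from compound 1 to compound 3 (0.06 log units; within the scatter) is small, within the scatter, in either direction. Compound 3 is expected to give 15 nM in this assay, with a range from 5 nM to 50 nM.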

Compound 3, half-maximal inhibitory concentration: 95 nM
Compound 3: middle estimate off by 6.3-fold (0.80 log units), on the low side, and the stated range ends below it.
By their numbers in this assay, from the lowest: compound 1; then compound 3; then compound 2.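

In this assay, within the data shown here, the place on a saturated chain carbon bound to a nitrogen on an aromatic ring proves sensitive to the arm it carries: pyridin-2-yl in place of pyrazin-2-yl gives a 7.2-fold higher number from compound 1 to compound 3 (0.86 log units; beyond the scatter), the first single-place step. The six-membered aromatic ring and the heavy-atom count stay the same, and the two arms differ by one ring nitrogen swapped for carbon, so a change this small is enough to move the number beyond the scatter. Nothing at hand gives a reason for this step.

Open, as far as these compounds go, is how a phenyl ring or a pyrimidin-2-yl group would read at this place on the core of compound 1. Also open, from the compounds shown here alone, is whether the same change gives a similar step with the methylfuran of compound 2 on the core.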